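The source may hold more compounds than are shown below. What is called first, only, known or untested is meant among the compounds shown, and "the series" means these compounds.

Measured compounds:
compound 1, `CC(Br)C(=O)Nc1ccc(F)c(C(=O)NC(N)=O)c1`: 520 nM
compound 2, `CC(Br)C(=O)Nc1ccc(Cl)c(C(=O)NC(N)=O)c1`: 2550 nM
compound 3, `NC(=O)NC(=O)c1ccc(F)c(NC(=O)CCl)c1`: a limit, > 20000 nM

In a functional assay on CCRF-CEM cells (Homo sapiens) for antiproliferative activity, read by trypan blue exclusion, with a stated time of 72 h (on this read-out lower numbers stand for stronger inhibition and higher numbers for weaker inhibition), compound 1 gives 520 nM and compound 2 gives 2550 nM. For compound 3 this assay reports no number but a limit, > 20000 nM. The change chloro in place of fluoro on an aromatic carbon produced a 4.9-fold higher number from compound 1 to compound 2 (0.69 log units; beyond the scatter). How the core of compound 1 and the core of compound 3 differ is not broken down here. Compound 4, `NC(=O)NC(=O)c1ccc(Cl)c(NC(=O)CCl)c1`, is made from compound 3 by chloro in place of fluoro on an aromatic carbon, the same kind of change, though here it sits ortho to a ((chloromethyl)carbonyl)amino group and para to a carbamoylcarbamoyl group. Given that compound 3 already sits at the limit (the limit of > 20000 nM in this assay, at which 1 of the 3 values shown sits), the step to compound 4 is expected to be a step that the limit leaves unreadable from compound 3 to compound 4 or again unresolved. Compound 4 is therefore estimated at 40000 nM, within 20000 nM to 100000 nM.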

Compound 4, half-maximal inhibitory concentration: 15900 nM
Compound 4: the middle estimate sits 2.5-fold (0.40 log units) above what was measured, and the stated range ends above it.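

In this assay, chloro in place of fluoro on an aromatic carbon gives an at least 1.2-fold lower number from compound 3 to compound 4 (0.09 log units; that floor lies within the scatter), whereas on the core of compound 1 the same change gives a 4.9-fold higher number from compound 1 to compound 2 (0.69 log units; beyond the scatter). The change therefore does not carry over from one core to the other with a single size: the same change on two cores in this assay, a 4.9-fold higher number (0.69 log units; beyond the scatter) from compound 1 to compound 2 and an at least 1.2-fold lower number (0.09 log units; that floor lies within the scatter) from compound 3 to compound 4, at least 6.1-fold (0.79 log units) apart, beyond the scatter of two such steps. It does not show the true size of the step on the core of compound 3, since compound 3 is known only as a limit and the floor of its step lies within the scatter: the limit of > 20000 nM in this assay, at which 1 of the 4 values shown sits.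

The compounds shown leave open how a methyl group or a nitrile on that aromatic carbon would compare with fluoro and chloro on either core.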